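Fluoro for Methoxy on the Phenyl of Compound 2

The source may report more compounds than this note shows. Statements on the series, on what has been measured and on what is new or still open speak of the compounds shown alone.

Measured compounds:
- compound 1, `O=c1c2ccccc2c(Nc2n[nH]c3ccccc23)nn1-c1ccccc1`: "not determined" (no result reported) in a functional assay on HCT-116 cells (Homo sapiens) for cytotoxicity, read by CellTiter-Glo, with a stated time of 5 days; a higher number here means a weaker inhibitor, a lower number a stronger inhibitor
- compound 2, `COc1ccc(-n2nc(Nc3cc(C)[nH]n3)c3ccccc3c2=O)cc1`: 700 nM

For the measured compounds named here, only two compounds are known here. Compound 1, with the structure `O=c1c2ccccc2c(Nc2n[nH]c3ccccc23)nn1-c1ccccc1`, has no number in this assay, so nothing can be said of its strength. Going by the values given here, compound 2, with the structure `COc1ccc(-n2nc(Nc3cc(C)[nH]n3)c3ccccc3c2=O)cc1`, gives 700 nM in this assay; it is the only compound with a number, so there is no neighbour against which to place it, and no step between measured compounds exists to show how large a change of this kind tends to be.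

Compound 3, `Cc1cc(Nc2nn(-c3ccc(F)cc3)c(=O)c3ccccc23)n[nH]1`, is not yet measured. It differs from compound 2 by fluoro in place of methoxy on an aromatic carbon. The change is small in count and sits at the edge of the molecule on the phenyl carried by the shared core, while the rest of the structure is untouched. Among the compounds with values here, with no measured step of any kind to lean on, the step of a 1.1-fold higher number from compound 2 to compound 3 (0.06 log units; within the scatter) is expected to stay within the usual scatter, with no direction claimed. For compound 3 the estimated value is 800 nM, with a range from 300 nM to 2500 nM.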

Compound 3, half-maximal inhibitory concentration: 800 nM
The estimate for compound 3 equals the measured number at the digits printed; the range from low to high includes it.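

In this assay, for the compounds shown here, the change from 4-methoxyphenyl to 4-fluorophenyl gives a 1.1-fold higher number from compound 2 to compound 3 (0.06 log units; within the scatter), the first measured step, and it shows that this place, on an aromatic carbon para to a large group, can carry either group with no difference beyond the scatter. Methoxy counts as a hydrogen-bond acceptor and fluoro does not, yet compound 2 and compound 3 cannot be told apart in this assay, so this one pair shows no link between that count at this place and the read-out. No measurement shown here accounts for how close the two numbers lie.

As far as these compounds go, whether an amine, a carboxylic acid or a longer chain such as butoxy at the same place would also leave the number within the scatter remains open, since two groups on a single pair define no trend. Compound 1 has no number in this assay, so the compounds shown also say nothing about how a change elsewhere on the shared core would bear on this cytotoxicity read-out.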